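Cytotoxicity of Amide Variants Sharing One Core

A few compounds are considered here, and "the series" means these few. Any claim that something is new, unique, unknown or untested is made for them only; others in the source may bear on it.

Compound 1, `COc1cc2c(cc1O)CCC(C)(CC(=O)N[C@@H](C)C(=O)O)O2`: 100%
Compound 2, `COc1cc2c(cc1O)CCC(C)(CC(N)=O)O2`: 100%

In an ADME assay on SH-SY5Y cells (Homo sapiens) for cytotoxicity, read by MTT assay, with a stated time of 24 h, tested at 3.1 uM (a lower number here means a stronger effect, a higher number a weaker effect of the compound at the concentration tested), compound 1 gives 100%. Compound 2, which carries a hydrogen in place of 1-carboxyethyl on the amide-type nitrogen, gives 100% in this assay. The step of no change at the digits printed from compound 1 to compound 2 (within the scatter) shows that swapping that group for a hydrogen left the read-out unchanged, so compound 2 stands level with compound 1 at the digits shown; the two values lie within the scatter of each other, and neither can be called the stronger or the weaker of the pair.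

Compound 3, `COc1cc2c(cc1O)CCC(C)(CC(=O)N[C@@H](CCC(N)=O)C(=O)O)O2`, has not yet been tested. It differs from compound 2 by 3-carbamoyl-1-carboxypropyl in place of hydrogen on an amide-type nitrogen. Within the data shown here, the only measured step that bears on this position is the one from compound 1 to compound 2, where changing the substituent on the same amide-type nitrogen produced no shift beyond the scatter. Putting a larger substituent back on that nitrogen is therefore expected to give a step of about no change at the digits printed from compound 2 to compound 3 (within the scatter), that is, none beyond the scatter. Compound 3 is estimated at 100% in this assay, with a range from 88% to 108%.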

Compound 3, a percentage reported as activity, at one concentration (the size of the read-out at that concentration, not a potency): 100%
Compound 3: the middle estimate sits on the measured number at the digits printed; the measured number falls inside the stated range.
By their numbers in this assay, from the lowest: compounds 1, 2 and 3 (each within the scatter of the next).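

In this assay, the 3-carbamoyl-1-carboxypropyl group on the amide-type nitrogen gives no change at the digits printed from compound 2 to compound 3 (within the scatter) and so reads level with the bare hydrogen, which extends what the smaller 1-carboxyethyl group had already suggested to a substituent of 9 heavy atoms with 2 hydrogen-bond donors. Compounds 1 and 3 also allow a second comparison, of carbamoylmethyl in place of hydrogen on a saturated chain carbon, two bonds along the chain from an amide-type nitrogen and a carbonyl carbon, and this gives no change at the digits printed from compound 1 to compound 3 (within the scatter) in the same assay, so lengthening that side chain does not separate the two compounds at the one concentration tested. Nothing available explains why these three compounds read alike.

On these data alone, all three compounds keep a carboxylic acid or a plain primary amide at this end of the molecule, so it stays open whether an amine, a phenyl ring or a long hydrocarbon chain on the same nitrogen would also read level. The shared core is also constant throughout, which leaves open what replacing its hydroxyl or methoxy group would do.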